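Phenyl to naphthalen-1-yl on the oxygen: working notes

The source may hold more compounds than are shown below. What is called first, only, known or untested is meant among the compounds shown, and "the series" means these compounds.

- compound 1 `CC(C)[C@H](NC(=O)COc1cccc2ccccc12)C(=O)N[C@@H](CC(=O)O)C(=O)COC(=O)c1c(Cl)cccc1Cl` gives 11500 nM in a functional assay with Homo sapiens as the target; a lower number here means a stronger inhibitor, a higher number a weaker inhibitor
- compound 2 `CC(C)[C@H](NC(=O)COc1cccc2ccccc12)C(=O)N[C@@H](CC(=O)O)C(=O)COc1ccccc1` gives 11200 nM in this assay

Compound 2 sits within the scatter of compound 1, and neither ranks ahead of the other. Compound 3 `CC(C)[C@H](NC(=O)COc1cccc2ccccc12)C(=O)N[C@@H](CC(=O)O)C(=O)COc1cccc2ccccc12`, not yet measured, carries naphthalen-1-yl in place of phenyl on an oxygen on a saturated carbon at that same place. For the measured compounds named here, the one measured step there (a 1.0-fold lower number from compound 1 to compound 2 (0.01 log units; within the scatter)) is phenyl in place of (2,6-dichlorophenyl)carbonyl. On that single step, no change beyond the scatter is expected in this assay. The estimated step is a 1.1-fold lower number from compound 2 to compound 3 (0.05 log units; within the scatter) and remains expected only. Compound 3 is expected at 10000 nM (range 4000 nM to 25000 nM).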

Compound 3, half-maximal inhibitory concentration: 19000 nM
Compound 3: middle estimate off by 1.9-fold (0.28 log units), on the low side, and the stated range covers the measured number.
By their numbers in this assay, from the lowest: compounds 2, 1 and 3 (each within the scatter of the next).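

Naphthalen-1-yl in place of phenyl gives a 1.7-fold higher number from compound 2 to compound 3 (0.23 log units; within the scatter) in this assay and in place of (2,6-dichlorophenyl)carbonyl gives a 1.7-fold higher number from compound 1 to compound 3 (0.22 log units; within the scatter) at this place, on an oxygen on a saturated carbon. A second six-membered aromatic ring on this oxygen therefore brings no step beyond the scatter, and all three groups read alike so far. No measurement at hand bears on the reason for this.

Still open, on these data alone, is whether an amine, a carboxylic acid or a longer chain in place of the aromatic group would move the number beyond the scatter.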